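Shrinking the sulfur-linked side chain of a pyrazole amine

The source may report more compounds than this note shows. Statements on the series, on what has been measured and on what is new or still open speak of the compounds shown alone.

Compound 1 `Cc1cc(Nc2cc(-c3ccccc3)[nH]n2)n2nc(SCc3ccc(F)cc3)nc2n1` is tested in a functional assay on MCF7 cells (Homo sapiens) for inhibition, read by MTT assay, with a stated time of 72 h (on this read-out higher numbers stand for weaker inhibition and lower numbers for stronger inhibition), where compound 1 gives 4020 nM. Among the three measured compounds it has the second highest number; compound 3 `Cc1cc(Nc2cc(-c3ccccc3)[nH]n2)n2nc(SCc3csc4ccccc34)nc2n1` gives 3470 nM, and a 1.2-fold lower number from compound 1 to compound 3 (0.06 log units; within the scatter). Compound 2 `C#CCSc1nc2nc(C)cc(Nc3cc(-c4ccccc4)[nH]n3)n2n1` gives 21800 nM, and a 5.4-fold higher number from compound 1 to compound 2 (0.73 log units; beyond the scatter). Compound 4 `CCCSc1nc2nc(C)cc(Nc3cc(-c4ccccc4)[nH]n3)n2n1` has not yet been measured; it differs from compound 1 in one place: ethyl in place of 4-fluorophenyl on a saturated chain carbon bound to a sulfur. Among the compounds with values here, the step that bears on it is the one from compound 1 to compound 2, where a small chain also replaced the 4-fluorophenyl group and gave a modest rise; the change from compound 2 to compound 3 points the same way. Compound 4 is therefore expected to show a weaker inhibition, with a 3.7-fold higher number from compound 1 to compound 4 (0.57 log units; beyond the scatter). The value of compound 4 in this assay is estimated at 15000 nM, likely between 6000 nM and 40000 nM.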

Compound 4, half-maximal inhibitory concentration: > 50000 nM
Compound 4 ended at the assay's limit; the forecaster's own chance of this, stated with the estimate: 10%; middle value at least 3.3-fold (0.52 log units) from the limit.
By their numbers in this assay, from the lowest: compounds 3 and 1 (each within the scatter of the next); then compound 2. At a limit, above all of these: compound 4.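

In this assay, within the data shown here, compound 4 sits at a limit, which is not a number: the limit of > 50000 nM in this assay, at which 1 of the 4 values shown sits. Replacing a ring-bearing end of the sulfur-linked chain with ethyl costs far more than the earlier steps showed, with an at least 12-fold higher number from compound 1 to compound 4 (1.09 log units; beyond the scatter) and an at least 14-fold higher number from compound 3 to compound 4 (1.15 log units; beyond the scatter). The two small chains also differ from each other, with an at least 2.2-fold higher number from compound 2 to compound 4 (0.36 log units; beyond the scatter), so ethynyl and ethyl are not interchangeable at this place.

On these data alone, the true size of these steps stays open while compound 4 has only a limit. As far as these compounds go, it is also open whether a longer chain, such as hexyl, or a chain ending in an amine would recover the inhibition.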